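Hydrazone aryl exchange: thiophene to 4-nitrophenyl

A few compounds are considered here, and "the series" means these few. Any claim that something is new, unique, unknown or untested is made for them only; others in the source may bear on it.

Measured compounds in a functional assay on ECa-109 cells (Homo sapiens) for antiproliferative activity, read by MTT assay, with a stated time of 72 h; a higher number here means a weaker inhibitor, a lower number a stronger inhibitor:
- compound 1 `CCCSc1nc(N/N=C(\C)c2ccc(O)cc2)c2nnn(Cc3ccccc3)c2n1` gives 32500 nM
- compound 2 `CCCSc1nc(N/N=C/c2cccs2)c2nnn(Cc3ccccc3)c2n1` gives > 64000 nM, which is a limit of the assay and not a number

For the measured compounds named here, compound 2 therefore stands at the edge of what this assay reports, and the only measured step reaching it, an at least 1.9-fold higher number from compound 1 to compound 2 (0.29 log units; that floor lies within the scatter), is itself bounded by that limit (the limit of > 64000 nM in this assay, at which 1 of the 2 values shown sits). Compound 3 `CCCSc1nc(N/N=C/c2ccc([N+](=O)[O-])cc2)c2nnn(Cc3ccccc3)c2n1` differs from compound 2 by 4-nitrophenyl in place of thiophen-2-yl on a carbon with a double bond to nitrogen. Going by the values given here, nothing among the measured steps sets a direction for this change, so no step beyond the scatter is expected. Compound 3 is thus expected to give 50000 nM, ranging from 15000 nM to 160000 nM, an estimated step of an at least 1.2-fold lower number from compound 2 to compound 3 (0.10 log units; that floor lies within the scatter).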

Compound 3, half-maximal inhibitory concentration: 6640 nM
Estimate against measurement, compound 3: 7.5-fold (0.88 log units) above; the measured number lies below the stated range.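

Exchanging thiophen-2-yl for 4-nitrophenyl gives an at least 9.6-fold lower number from compound 2 to compound 3 (0.98 log units; beyond the scatter) in this assay and so shows that the group on the carbon with a double bond to nitrogen can change activity in this series. For the compounds shown here, the only earlier step had a floor within the scatter, so this is the first step here that clearly sets a direction. Its size remains a floor, as compound 2 stands at a limit and not at a number: the limit of > 64000 nM in this assay, at which 1 of the 3 values shown sits.

The compounds shown leave open whether the nitro group or the six-membered aromatic ring accounts for this step. Unsubstituted phenyl or 4-aminophenyl at this place would separate the two.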